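The compounds below may be only part of what the source reports. "The series", "measured", "known", "first", "only" and "open" are said of these compounds alone.

Compound 1 `Cn1c(=O)c(=O)n(C2CCCC2)c2nc(N/N=C/c3ccccc3)ncc21` gives 48200 nM in a functional assay on PC-3 cells (Homo sapiens) for antiproliferative activity, read by MTT assay; on this read-out lower numbers stand for stronger inhibition and higher numbers for weaker inhibition.
Compound 2 `Cn1c(=O)c(=O)n(C2CCCC2)c2nc(N/N=C/c3ccc(F)c(Cl)c3)ncc21` gives 8550 nM in this assay.
Compound 3 `Cn1c(=O)c(=O)n(C2CCCC2)c2nc(N/N=C/c3ccc(O)c(F)c3)ncc21` gives 85200 nM in this assay.

Compound 3 stands highest of these three numbers: nearest to it is compound 1, a gap within the scatter, and furthest is compound 2, as the step of a 10-fold higher number from compound 2 to compound 3 (1.00 log units; beyond the scatter) shows. Compound 4 `COc1cccc(/C=N/Nc2ncc3c(n2)n(C2CCCC2)c(=O)c(=O)n3C)c1` differs from compound 3 by 3-methoxyphenyl in place of 3-fluoro-4-hydroxyphenyl on a carbon with a double bond to nitrogen. Among the compounds with values here, no measured step swaps exactly these two rings. Within the data shown here, the steps that bear on it are a 1.8-fold higher number from compound 1 to compound 3 (0.25 log units; within the scatter) and a 10-fold higher number from compound 2 to compound 3 (1.00 log units; beyond the scatter); they place the hydroxy-bearing ring near plain phenyl and far from the chloro-fluoro ring. A 3-methoxyphenyl ring, with no hydrogen-bond donor like plain phenyl, is therefore expected to give a number near that of compound 1 or compound 3. Compound 4 is estimated at 45000 nM, with a range from 12000 nM to 150000 nM, an expected step of a 1.9-fold lower number from compound 3 to compound 4 (0.28 log units; within the scatter) that need not exceed the scatter.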

Compound 4, half-maximal inhibitory concentration: 20700 nM
Estimate against measurement, compound 4: 2.2-fold (0.34 log units) above; the range from low to high includes it.
By their numbers in this assay, from the lowest: compound 2; then compound 4; then compounds 1 and 3 (each within the scatter of the next).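

In this assay, methoxy in place of hydrogen on an aromatic carbon gives a 2.3-fold lower number from compound 1 to compound 4 (0.37 log units; beyond the scatter), so this position responds to a change that keeps the plain ring and adds one group. Swapping the 3-fluoro-4-hydroxyphenyl ring for 3-methoxyphenyl gives a 4.1-fold lower number from compound 3 to compound 4 (0.61 log units; beyond the scatter), yet the 3-chloro-4-fluorophenyl ring keeps its lead, with a 2.4-fold higher number from compound 2 to compound 4 (0.38 log units; beyond the scatter). Nothing measured here explains these steps. The compounds shown leave open whether a ring bearing an amine or a carboxylic acid would fall below compound 2. They also leave unsettled what the hydroxy and fluoro groups of compound 3 each contribute.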